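This account rests on a few compounds, and the source may have more. Where it says the series, first, only, none or still open, it means among the compounds named here.

Measured in a physicochemical assay for lipophilicity; a higher number here means a more lipophilic compound, a lower number a more polar compound:
Compound 1 `C[C@H]1CC[C@@H]2[C@@H](OC(=O)[C@]23CC(c2ccc([N+](=O)[O-])cc2)=NO3)[C@]2(C)C(=O)C=C[C@@]12O`: 1.37
Compound 2 `Cc1ccc(C2=NO[C@]3(C2)C(=O)O[C@@H]2[C@H]3CC[C@H](C)[C@]3(O)C=CC(=O)[C@@]23C)cc1`: 1.86
Compound 3 `C[C@H]1CC[C@@H]2[C@@H](OC(=O)[C@]23CC(c2ccc(F)cc2)N(c2ccccc2)O3)[C@]2(C)C(=O)C=C[C@@]12O`: 3.35

Compound 3 stands highest of the three in this assay, at 3.35, clearly beyond the scatter from both others. Compound 4 `C[C@H]1CC[C@@H]2[C@@H](OC(=O)[C@]23CC(c2cccc(Cl)c2)N(c2ccccc2)O3)[C@]2(C)C(=O)C=C[C@@]12O` carries 3-chlorophenyl in place of 4-fluorophenyl on a saturated ring carbon. Among the measured compounds shown here, no measured step shows this exchange. The nearest guide is the modest a number 0.49 log units higher from compound 1 to compound 2 (beyond the scatter), which lies beyond the scatter and also swaps one substituent for another, though on an aromatic carbon. A rise of similar modest size is therefore expected, and the estimated change is a number 0.45 log units higher from compound 3 to compound 4 (beyond the scatter). Compound 4 is expected at 3.8, with an estimated range of 3.4 to 4.25.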

Compound 4, partition coefficient: 3.87
For compound 4 the middle estimate is 0.07 log units below the measured one, and the stated range covers the measured number.
By their numbers in this assay, from the lowest: compound 1; then compound 2; then compound 3; then compound 4.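

In this assay, placing 3-chlorophenyl in place of 4-fluorophenyl on the saturated ring carbon gives a number 0.52 log units higher from compound 3 to compound 4 (beyond the scatter), the first step shown at this position. The two groups match in heavy atoms and in hydrogen-bond donors and acceptors, so the number at this position moves without any change in those counts. Nothing available here accounts for the rise. The halogen and its place on the phenyl change together, leaving open what each does alone, as 4-chlorophenyl would show. From the compounds shown here alone, how an amine or a carboxylic acid on this phenyl would read also remains open.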